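Replacing furan-2-yl with 1H-indol-6-yl

This account rests on a few compounds, and the source may have more. Where it says the series, first, only, none or still open, it means among the compounds named here.

Values so far in a toxicity assay on MT4 cells (Homo sapiens) for cytotoxicity, read by MTT assay, with a stated time of 5 days; on this read-out higher numbers stand for lower toxicity in this test and lower numbers for higher toxicity in this test:
- Compound 1 `Cc1cnc(Nc2ccc(C#N)cc2)nc1Nc1c(F)cc(-c2cccnc2)cc1F` gives 1100 nM
- Compound 2 `Cc1cnc(Nc2ccc(C#N)cc2)nc1Nc1c(F)cc(-c2ccoc2)cc1F` gives 4200 nM
- Compound 3 `Cc1cc(-c2ccco2)cc(C)c1Nc1ccnc(Nc2ccc(C#N)cc2)n1` gives 1700 nM

Compound 3 (1700 nM) cannot be told apart from compound 1 (1100 nM), while compound 2 (4200 nM) shows a higher number than compound 3. Next comes compound 4 `Cc1cc(-c2ccc3cc[nH]c3c2)cc(C)c1Nc1ccnc(Nc2ccc(C#N)cc2)n1`, where 1H-indol-6-yl takes the place of furan-2-yl on an aromatic carbon (1H-indol-6-yl in place of furan-2-yl on an aromatic carbon). Within the data shown here, only one measured step swaps one aromatic group for another, and it is modest: a 3.8-fold higher number from compound 1 to compound 2 (0.58 log units; beyond the scatter), with furan-3-yl in place of pyridin-3-yl. Among the measured compounds shown here, its core differs from that of compound 3, and no measured compound carries 1H-indol-6-yl, so the guidance is weak. Read in reverse, that step leads from a furan to a group with a six-membered ring and to a lower number. A modest step downward in this assay is therefore expected, though it may stay within the scatter. For compound 4 the estimated value is (1000 nM), with an expected range from 300 nM to 4000 nM. The expected step is (a 1.7-fold lower number from compound 3 to compound 4 (0.23 log units; within the scatter)).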

Compound 4, half-maximal cytotoxic concentration: 5800 nM
For compound 4 the middle estimate is 5.8-fold (0.76 log units) below the measured one; the whole stated range lies below it.
By their numbers in this assay, from the lowest: compounds 1 and 3 (each within the scatter of the next); then compounds 2 and 4 (each within the scatter of the next).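

In this assay, moving to the two-ring 1H-indol-6-yl on this aromatic carbon gives a clear change (a 3.4-fold higher number from compound 3 to compound 4 (0.53 log units; beyond the scatter)), so at this position, para to a large group, the bigger group does not bring higher toxicity in this test. Among these compounds, the only earlier swap of one aromatic group for another (a 3.8-fold higher number from compound 1 to compound 2 (0.58 log units; beyond the scatter)) ended on a furan with the higher number, on a different core, whereas here the furan-bearing compound has the lower number, so no single ranking of these groups carries over. Nothing measured here explains the rise.

As far as these compounds go, it remains open whether the second ring or the hydrogen-bond donor of the indole goes with the change. Naphthalen-2-yl, with two rings of carbon only, would separate the two.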